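A few compounds are considered here, and "the series" means these few. Any claim that something is new, unique, unknown or untested is made for them only; others in the source may bear on it.

Compound 2 `COc1nc2ccccc2cc1/C=C/c1noc(-c2ccc(F)cc2)n1` is one of three measured compounds sharing a common core. In an ADME assay on HepG2 cells (Homo sapiens) for cytotoxicity, read by sulforhodamine B assay, with a stated time of 48 h (a lower number here means that less compound is tolerated, a higher number that more compound is tolerated), compound 2 gives > 230000 nM, which is a limit of the assay and not a number. Compound 1 `COc1ccc(-c2nc(/C=C/c3cc4ccccc4nc3OC)no2)cc1` gives > 220000 nM in this assay, again a limit. Compound 3 `COc1nc2ccccc2cc1/C=C/c1noc(/C=C/c2ccccc2)n1` gives > 225000 nM in this assay, also a limit. So compound 2 stands level with its neighbours, all three sitting at limits. The steps a step that the two limits leave unreadable from compound 1 to compound 2, a step that the two limits leave unreadable from compound 1 to compound 3 and a step that the two limits leave unreadable from compound 2 to compound 3 are therefore unreadable in size and direction because every value involved is a limit, as the limit of > 220000 nM in this assay, at which 1 of the 3 values shown sits, the limit of > 225000 nM in this assay, at which 1 of the 3 values shown sits, and the limit of > 230000 nM in this assay, at which 1 of the 3 values shown sits, show.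

Compound 4 `COc1nc2ccccc2cc1/C=C/c1noc(-c2cccnc2)n1` differs from compound 2 by pyridin-3-yl in place of 4-fluorophenyl on an aromatic carbon. Among the compounds with values here, the steps that bear on this change, from compound 1 to compound 2 and from compound 2 to compound 3, both vary the group at the same position and both are unreadable. No readable step exists, so no shift beyond the scatter is expected in this assay. Compound 4 is thus expected to give 230000 nM in this assay, between 100000 nM and 300000 nM, most likely as another limit. The expected step is a number no higher from compound 2 to compound 4 (the limit leaves the size open).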

Compound 4, half-maximal cytotoxic concentration: > 240000 nM
Compound 4: only a limit was reported; the forecaster's own chance of this, stated with the estimate: 80%; at least 1.0-fold (0.01 log units) between middle value and limit.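

In this assay compound 4 gives > 240000 nM, which is a limit of the assay and not a number. Its steps from compound 1, compound 2 and compound 3 cannot be read in size or direction. The compounds shown leave open whether the groups compared here differ at all in this assay, and at what concentration any of these four compounds would reach the half-maximal read-out.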